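Methoxyphenyl variation on a shared enone-linked core

The compounds below may be only part of what the source reports. "The series", "measured", "known", "first", "only" and "open" are said of these compounds alone.

All three measured compounds share one core and differ only in the methoxyphenyl on a double-bonded chain carbon bound to a double-bonded chain carbon. In a functional assay on P338 cells (Mus musculus) for antiproliferative activity (on this read-out lower numbers stand for stronger inhibition and higher numbers for weaker inhibition), compound 1 `COc1ccc(/C=C/C(=O)c2ccc(OCCn3cc(CN4C(=O)/C=C/C(C)(C)C/C=C(\C)CC/C=C/4C)nn3)cc2O)cc1` gives 1.21 ug/mL, compound 2 `COc1cccc(/C=C/C(=O)c2ccc(OCCn3cc(CN4C(=O)/C=C/C(C)(C)C/C=C(\C)CC/C=C/4C)nn3)cc2O)c1` gives 0.89 ug/mL, and compound 3 `COc1ccccc1/C=C/C(=O)c1ccc(OCCn2cc(CN3C(=O)/C=C/C(C)(C)C/C=C(\C)CC/C=C/3C)nn2)cc1O` gives 1.1 ug/mL. Compound 3 sits in the same band as both neighbours: a 1.1-fold lower number from compound 1 to compound 3 (0.04 log units; within the scatter) and a 1.2-fold higher number from compound 2 to compound 3 (0.09 log units; within the scatter), while a 1.4-fold lower number from compound 1 to compound 2 (0.13 log units; within the scatter). Compound 4 `COc1cc(/C=C/C(=O)c2ccc(OCCn3cc(CN4C(=O)/C=C/C(C)(C)C/C=C(\C)CC/C=C/4C)nn3)cc2O)cc(OC)c1OC` carries the change (3,4,5-trimethoxyphenyl in place of 2-methoxyphenyl on a double-bonded chain carbon bound to a double-bonded chain carbon). On these data alone, the three measured steps, each exchanging one methoxyphenyl for another, all stayed within the scatter; none adds methoxy groups, so the effect of two further ones is untested. For compound 4 a step within the scatter is expected, a 1.1-fold lower number from compound 3 to compound 4 (0.04 log units; within the scatter). Compound 4 is estimated at 1 ug/mL, with a range from 0.45 ug/mL to 2.4 ug/mL.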

Compound 4, half-maximal inhibitory concentration: 0.89 ug/mL
Compound 4: the middle estimate sits 1.1-fold (0.05 log units) above what was measured; measured number inside the range.
By their numbers in this assay, from the lowest: compounds 2, 4, 3 and 1 (each within the scatter of the next).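

Going from one methoxy group to three on this aryl ring leaves the number within the scatter in this assay against all three earlier compounds (a 1.2-fold lower number from compound 3 to compound 4 (0.09 log units; within the scatter)) (no change at the digits printed from compound 2 to compound 4 (within the scatter)) (a 1.4-fold lower number from compound 1 to compound 4 (0.13 log units; within the scatter)). The read-out therefore does not separate 3,4,5-trimethoxyphenyl, with 12 heavy atoms, from the 8-atom methoxyphenyl groups. No supporting data bear on this result.

On these data alone, all four compounds carry only methoxy groups on the phenyl, so the effect of a different substituent at this place, such as an amine or a carboxylic acid, remains open.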